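A hydroxymethyl in place of the carboxy group

A few compounds are considered here, and "the series" means these few. Any claim that something is new, unique, unknown or untested is made for them only; others in the source may bear on it.

Measured so far:
Compound 1 `CC(=O)NCC[C@@H]1C[C@@H](c2ccc(F)c(F)c2)[C@H](NC(=O)c2cc(-c3c(Cl)cnn3C)c(Cl)o2)CN1` gives 880 nM in a functional assay on OVCAR-8 cells (Homo sapiens) for antiproliferative activity; a lower number here means a stronger inhibitor, a higher number a weaker inhibitor.
Compound 2 `Cn1ncc(Cl)c1-c1cc(C(=O)N[C@@H]2CN[C@H](CC(=O)O)C[C@H]2c2ccc(Cl)c(Cl)c2)oc1Cl` gives 5120 nM in this assay.
Compound 3 `CNC(=O)C[C@@H]1C[C@@H](c2ccc(F)c(F)c2)[C@H](NC(=O)c2cc(-c3c(Cl)cnn3C)c(Cl)o2)CN1` gives 800 nM in this assay.

Among these three, compound 2 gives the highest number, and its gap to both compound 1 and compound 3 lies beyond the usual scatter, so it is the weakest of the measured set. Compound 4 `Cn1ncc(Cl)c1-c1cc(C(=O)N[C@@H]2CN[C@H](CCO)C[C@H]2c2ccc(Cl)c(Cl)c2)oc1Cl` is its untested relative. The change from compound 2 to compound 4 is hydroxymethyl in place of carboxy on a saturated chain carbon bound to a saturated ring carbon.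

Within the data shown here, only one measured step touches the same place on the chain, the move from compound 1 to compound 3, which gave a 1.1-fold lower number from compound 1 to compound 3 (0.04 log units; within the scatter). It shows that swapping one group for another at this position need not shift the number. Among the measured compounds shown here, compounds 1 and 3, however, differ from compound 2 in more than one place, so no step from compound 2 to either of them can be read off directly; their values show only that compounds without the carboxy group sit well below compound 2. On that basis a modest drop in the number for compound 4 is expected, a 2.8-fold lower number from compound 2 to compound 4 (0.45 log units; beyond the scatter), with wide uncertainty. Compound 4 is estimated at 1800 nM, within a range from 600 nM to 5000 nM.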

Compound 4, half-maximal inhibitory concentration: 610 nM
Compound 4: the middle estimate sits 3.0-fold (0.47 log units) above what was measured; the range from low to high includes it.
By their numbers in this assay, from the lowest: compounds 4, 3 and 1 (each within the scatter of the next); then compound 2.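

Among these compounds, until now, the only step at this position was a 1.1-fold lower number from compound 1 to compound 3 (0.04 log units; within the scatter), which might have suggested that the number in this assay barely responds to what sits on this chain. The new step, an 8.4-fold lower number from compound 2 to compound 4 (0.92 log units; beyond the scatter), shows otherwise: replacing carboxy with hydroxymethyl on a saturated chain carbon bound to a saturated ring carbon moves the number well beyond the scatter. Compound 2 also differs from compound 1 and compound 3 in more than one place, so their values could not isolate the carboxy group, whereas compound 2 and compound 4 differ only by this swap, which links the improvement directly to the change at this position.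

Still open, on these data alone, is how an amine, a methyl ether or a longer chain ending in a hydroxyl would behave at this place, and whether the same swap would give a similar step on the core of compound 1 or compound 3. The data shown offer no measurement that explains why this change lowers the number.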